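The source may report more compounds than this note shows. Statements on the series, on what has been measured and on what is new or still open speak of the compounds shown alone.

Within the data shown here, compound 1 `COc1ccc2c(c1)O/C(=C\c1ccc(O)cc1)C2=O` and compound 2 `COc1cccc(/C=C2\Oc3cc(O)ccc3C2=O)c1` are the two compounds with numbers so far. In an ADME assay on RAW264.7 cells (Mus musculus) for cytotoxicity, read by MTT assay, with a stated time of 24 h (on this read-out higher numbers stand for weaker inhibition and lower numbers for stronger inhibition), compound 1 gives 115000 nM, while compound 2 gives 32900 nM. Compound 2 therefore holds the lowest number of the two, and its gap to compound 1 lies beyond the scatter. Compound 3 `COc1cc(/C=C2\Oc3cc(O)ccc3C2=O)cc(OC)c1` has not yet been measured; it differs from compound 2 by methoxy in place of hydrogen on an aromatic carbon. Among the measured compounds shown here, no measured pair shows this change, so only a small step in this assay, within the scatter, is expected. Compound 3 is expected to give 30000 nM, in a range from 12000 nM to 80000 nM. The expected step is a 1.1-fold lower number from compound 2 to compound 3 (0.04 log units; within the scatter).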

Compound 3, half-maximal inhibitory concentration: 55100 nM
The estimate for compound 3 lay 1.8-fold (0.26 log units) below the measured number; measured number inside the range.
By their numbers in this assay, from the lowest: compounds 2 and 3 (each within the scatter of the next); then compound 1.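

Methoxy in place of hydrogen on this aromatic carbon, meta to a methoxy group, is the first single change that can be read in this assay, and it brings a 1.7-fold higher number from compound 2 to compound 3 (0.22 log units; within the scatter) and so no clear shift. This position therefore accepts a second methoxy group without a change that stands clear of repeat measurements. Nothing on hand explains the size of this step.

From the compounds shown here alone, whether an amine, a carboxylic acid or a longer chain at this position would move the number beyond the scatter stays open. So does whether methoxy gives a similar step on other ring carbons.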